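This account rests on a few compounds, and the source may have more. Where it says the series, first, only, none or still open, it means among the compounds named here.

In an ADME assay on HepG2 cells (Homo sapiens) for cytotoxicity (on this read-out lower numbers stand for higher toxicity in this test and higher numbers for lower toxicity in this test), three compounds have been measured so far. Compound 1 `CSc1cccc(N2C(=O)CN(c3cccc(C#N)c3)CC2C(=O)NC2CCCC2)c1` gives > 50000 nM, which is a limit of the assay and not a number. Compound 3 `O=C(NC1CCC1)C1CN(c2ccccc2)CC(=O)N1c1ccc2ccsc2c1` gives > 50000 nM, and this too is only a limit. Compound 2 `O=C(NC1CCCC1)[C@@H]1CN(c2ccc(C(F)(F)F)cc2)CC(=O)N1c1ccc2ccsc2c1` is the only one of the three with a number, at 20000 nM. Compound 3 therefore has no exact value and stands at the limit of > 50000 nM in this assay, at which 2 of the 3 values shown sit.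

Compound 4 `N#Cc1cccc(NC(=O)C2CN(c3ccccc3)CC(=O)N2c2ccc3ccsc3c2)c1` keeps the core of compound 3 and alters only the group on the amide: 3-cyanophenyl in place of cyclobutyl on an amide-type nitrogen. Put simply, 3-cyanophenyl takes the place of cyclobutyl on an amide-type nitrogen. Going by the values given here, no measured pair of compounds isolates this change, so its effect cannot be read directly from the data. Among the compounds with values here, the only guide to how far a related structure can fall is compound 2 at 20000 nM. On that basis, the step of an at least 1.4-fold lower number from compound 3 to compound 4 (0.15 log units; that floor lies within the scatter) is expected to be modest, if it can be seen at all, and to point towards lower numbers, meaning higher toxicity in this assay. A reading that again reaches the limit of the assay would be no surprise. For compound 4 the estimated value is 35000 nM, with an expected range from 15000 nM to 50000 nM.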

Compound 4, half-maximal cytotoxic concentration: > 50000 nM
Compound 4: no number, only a limit (the forecaster's own chance of this, stated with the estimate: 55%); at least 1.4-fold (0.15 log units) between middle value and limit.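

In this assay, going by these compounds alone, compound 3 and compound 4 both end at a limit of the assay and not at a number, so no step between them can be read: the limit of > 50000 nM in this assay, at which 3 of the 4 values shown sit. The compounds shown leave open whether 3-cyanophenyl in place of cyclobutyl on an amide-type nitrogen changes the read-out at all.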